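From Bromo to 2-Cyanoethenyl on the Amino Compound

A few compounds are considered here, and "the series" means these few. Any claim that something is new, unique, unknown or untested is made for them only; others in the source may bear on it.

Among the measured compounds shown here, in an ADME assay on MT2 cells (Homo sapiens) for cytotoxicity, read by XTT assay, with a stated time of 4 days (on this read-out higher numbers stand for lower toxicity in this test and lower numbers for higher toxicity in this test), compound 1 (`Cc1cc(Br)cc(C)c1Oc1ccc([N+](=O)[O-])c(Nc2ccc(C#N)cc2)n1`) gives 65100 nM as one of only two true numbers in this small set. Compound 2 (`CC(=O)/C=C/c1cc(C)c(Oc2ccc([N+](=O)[O-])c(Nc3ccc(C#N)cc3)n2)c(C)c1`) carries a limit of > 47900 nM and not a number. Compound 3 (`Cc1cc(Br)cc(C)c1Oc1ccc(N)c(Nc2ccc(C#N)cc2)n1`) gives 9610 nM as the lower of the two numbers, and compound 1 is its nearest neighbour. Amino in place of nitro on an aromatic carbon gives a 6.8-fold lower number from compound 1 to compound 3 (0.83 log units; beyond the scatter) and sets this starting point, though that change lies elsewhere on the molecule.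

Compound 4 (`Cc1cc(/C=C/C#N)cc(C)c1Oc1ccc(N)c(Nc2ccc(C#N)cc2)n1`) keeps that amino group and the shared core. It departs from compound 3 at one place (2-cyanoethenyl in place of bromo on an aromatic carbon), with 2-cyanoethenyl in place of bromo on an aromatic carbon, meta to two methyl groups. The closest measured change puts a different group, 2-acetylethenyl, at that place on the nitro compound, and it offers only a step that the limit leaves unreadable from compound 1 to compound 2 as a guide. With that single unreadable step to go on, no step beyond the scatter is expected in this assay and no direction can be favoured. The expected outcome is a 1.1-fold lower number from compound 3 to compound 4 (0.03 log units; within the scatter) and nothing larger. Compound 4 is therefore estimated at 9000 nM (expected range 3000 nM to 30000 nM).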

Compound 4, half-maximal cytotoxic concentration: 5630 nM
Beside the measured number, compound 4's estimate is 1.6-fold (0.20 log units) above it, and the stated range covers the measured number.
By their numbers in this assay, from the lowest: compounds 4 and 3 (each within the scatter of the next); then compound 1.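

In this assay, among the compounds shown here, 2-cyanoethenyl in place of bromo gives a 1.7-fold lower number from compound 3 to compound 4 (0.23 log units; within the scatter), the first readable step at this position, para to a large group. It shows that, on the amino compound, a bromo of 1 heavy atom can give way to a group of 4 heavy atoms, with a double bond and a triple bond, and the number stays within the scatter. For the compounds shown here, the only earlier step at this position cannot be read, and compound 2 holds a limit and not a number: the limit of > 47900 nM in this assay, at which 1 of the 4 values shown sits.

On these data alone, it remains open whether 2-cyanoethenyl gives a similarly small step on the nitro compound, and whether 2-acetylethenyl on the amino compound gives a readable number in this assay. Also open is how this position would read with a saturated 2-cyanoethyl chain, a carboxylic acid or an amine in place of bromo, as the compounds shown carry only bromo and two unsaturated chains there.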